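Swapping ethyl for cyclopropyl on compound 2

This account rests on a few compounds, and the source may have more. Where it says the series, first, only, none or still open, it means among the compounds named here.

Measured in a functional assay on SW1573 cells (Homo sapiens) for antiproliferative activity, read by sulforhodamine B assay, with a stated time of 48 h; a higher number here means a weaker inhibitor of growth, a lower number a stronger inhibitor of growth:
Compound 1 `COC(=O)C#CC(O/C=C/C(=O)OC)C(C)c1ccccc1`: 1200 nM
Compound 2 `CCC(C#CC(=O)OC)O/C=C/C(=O)OC`: 540 nM
Compound 3 `COC(=O)C#CC(C[C@@H](C)CCC=C(C)C)O/C=C/C(=O)OC`: 2200 nM

Of these three, compound 2 has the lowest number, so it stops growth at the lowest concentration. Compound 4 `COC(=O)C#CC(O/C=C/C(=O)OC)C1CC1` has not been measured yet. Its difference from compound 2 is this: cyclopropyl in place of ethyl on a saturated chain carbon bound to an oxygen on an unsaturated carbon and a triple-bonded carbon. The change sits on a saturated chain carbon bound to an oxygen on an unsaturated carbon and a triple-bonded carbon. Within the data shown here, no measured step swaps ethyl for a ring. The nearest guide is a 2.2-fold lower number from compound 1 to compound 2 (0.35 log units; beyond the scatter), which puts hydrogen in place of phenyl, at a different place. Among the measured compounds shown here, with only that modest step to go on, no change beyond the scatter is expected in this assay. The expected step is a 1.1-fold higher number from compound 2 to compound 4 (0.05 log units; within the scatter). Compound 4 is estimated at 600 nM, with an expected range of 280 nM to 1300 nM.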

Compound 4, concentration for 50% growth inhibition: 1800 nM
The estimate for compound 4 lay 3.0-fold (0.48 log units) below the measured number, and the stated range ends below it.
By their numbers in this assay, from the lowest: compound 2; then compounds 1, 4 and 3 (each within the scatter of the next).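

In this assay, the saturated chain carbon bound to an oxygen on an unsaturated carbon and a triple-bonded carbon proves sensitive to a small change: cyclopropyl in place of ethyl gives a 3.3-fold higher number from compound 2 to compound 4 (0.52 log units; beyond the scatter). Going from 2 heavy atoms to 3 here is thus enough to move the number beyond the scatter. Nothing measured here gives a reason for this.

The compounds shown leave open whether the ring itself or the extra carbon matters, which a propyl chain at this place could separate. Going by these compounds, how an amine here would compare also stays open.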